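Pyridin-2-yl for Phenyl on the Ring Nitrogen

The compounds below may be only part of what the source reports. "The series", "measured", "known", "first", "only" and "open" are said of these compounds alone.

Measured compounds:
compound 1 `CC(C)(C)c1cc2nn(-c3ccccc3)c(N)c2c(=O)[nH]1`, -1%
compound 2 `Nc1c2c(=O)[nH]c(-c3ccccc3)cc2nn1-c1ccccc1`, 13%
compound 3 `COc1ccccc1-c1cc2nn(-c3ccccc3)c(N)c2c(=O)[nH]1`, 7%

These three compounds were tested in an assay on isolated protein for inhibition of ribosomal protein S6 kinase alpha-5 (Homo sapiens), read by mobility shift assay, tested at 30 uM; a higher number here means more inhibition at the concentration tested (going by the name of the read-out), a lower number less inhibition. Compound 2 holds the highest of the three numbers with 13%; the gap to its nearest neighbour is a number 6 percentage points lower from compound 2 to compound 3 (within the scatter), and the gap to the furthest is a number 14 percentage points higher from compound 1 to compound 2 (beyond the scatter). Compound 4 `Nc1c2c(=O)[nH]c(-c3ccccc3)cc2nn1-c1ccccn1` has not yet been measured; it differs from compound 2 in one place: pyridin-2-yl in place of phenyl on an aromatic nitrogen. The measured steps all concern the group on an aromatic carbon of the shared core: a number 14 percentage points higher from compound 1 to compound 2 (beyond the scatter) and a number 8 percentage points higher from compound 1 to compound 3 (within the scatter). Within the data shown here, neither touches the group on the aromatic nitrogen, so no measured step bears directly on this change. All three numbers sit low, and there is no guide for this position. The expected step in this assay is a number 2 percentage points lower from compound 2 to compound 4 (within the scatter), which is none beyond the scatter. Compound 4 is therefore estimated at 11%, within a range of -5% to 27%.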

Compound 4, a percentage reported as inhibition, at one concentration (the size of the read-out at that concentration, not a potency): -4%
Compound 4: middle estimate off by 15 percentage points, on the high side; measured number inside the range.
By their numbers in this assay, from the lowest: compounds 4, 1, 3 and 2 (each within the scatter of the next, the first and the last beyond it).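

Among these compounds, changing the group on the aromatic nitrogen moved the number in this assay, with a number 17 percentage points lower from compound 2 to compound 4 (beyond the scatter), so this position responds to substitution even though all the earlier steps concerned the group on an aromatic carbon. Phenyl and pyridin-2-yl have the same count of heavy atoms, and the change replaces a ring carbon with a ring nitrogen, so a swap that leaves the size of the group unchanged is enough to give this step. Nothing available gives a reason for the step.

On these data alone, it remains open whether pyridin-3-yl or pyridin-4-yl on this nitrogen would give a similar step, which would show whether the placing of the ring nitrogen matters. As far as these compounds go, it is equally open how the number would respond to a methyl or a benzyl group here.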